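The source may hold more compounds than are shown below. What is called first, only, known or untested is meant among the compounds shown, and "the series" means these compounds.

Compound 1, `COc1cccc2sc(NC(=O)c3ccc(C(F)(F)F)cc3)nc12`: in a functional assay on MDA-MB-231 cells (Homo sapiens) for antiproliferative activity, read by sulforhodamine B assay (a higher number here means a weaker inhibitor of growth, a lower number a stronger inhibitor of growth), compound 1 gives > 10 ug/mL, which is a limit of the assay and not a number.
Compound 2, `Cc1cc(C)c2sc(NC(=O)c3ccc([N+](=O)[O-])cc3)nc2c1`: in this assay compound 2 gives 0.29 ug/mL.
Compound 3, `COc1ccc2sc(NC(=O)c3ccc([N+](=O)[O-])cc3)nc2c1`: in this assay compound 3 gives > 10 ug/mL, again only a limit.

Compound 3 thus stands at the limit of > 10 ug/mL in this assay, at which 2 of the 3 values shown sit, so no number is available for it, and nothing measured separates it from compound 1. Compound 2 alone comes with a numerical value in this assay. Within the data shown here, no pair of measured compounds differs in a single place, so no measured step exists to lean on.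

Compound 4, `COc1ccc2sc(NC(=O)c3ccc(C#N)cc3)nc2c1`, differs from compound 3 by cyano in place of nitro on an aromatic carbon. With both neighbours of this change sitting at a limit, the step is expected to be small, with no direction beyond the scatter, and a step that the limit leaves unreadable from compound 3 to compound 4 is the estimate for it. Compound 4 is therefore expected to give about 15 ug/mL in this assay, with a range from 4 ug/mL to 50 ug/mL, and most likely only a limit again.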

Compound 4, concentration for 50% growth inhibition: > 10 ug/mL
Compound 4 was reported as a limit; the forecaster's own chance of this, stated with the estimate: 70%; the middle value does not contradict the limit.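

No step can be read from compound 3 to compound 4, as both stand at a limit and not at a number: the limit of > 10 ug/mL in this assay, at which 3 of the 4 values shown sit.

The compounds shown leave open whether cyano in place of nitro changes growth inhibition at all, and which structural feature gives compound 2 its numerical value.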